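The source may hold more compounds than are shown below. What is called first, only, known or untested is meant among the compounds shown, and "the series" means these compounds.

Measured in a functional assay on K562 cells (Homo sapiens) for cytotoxicity, read by sulforhodamine B assay, with a stated time of 48 h; on this read-out lower numbers stand for stronger inhibition and higher numbers for weaker inhibition:
- compound 1 `O=C(c1ccc2nc(NC(=O)C(F)(F)F)cn2c1)c1ccc(C(F)(F)F)cc1F`: 56600 nM
- compound 2 `Cc1ccc(F)c(C(=O)c2ccc3nc(NC(=O)C(F)(F)F)cn3c2)c1`: 83200 nM
- compound 3 `Cn1cc(C(=O)c2ccc3nc(NC(=O)C(F)(F)F)cn3c2)c2ccccc21`: 54600 nM

Compound 2 holds the highest number of the three, yet its gaps to compound 1 and compound 3 lie within the scatter, so the set shows no real separation. Compound 4 `O=C(c1ccc2nc(NC(=O)C(F)(F)F)cn2c1)c1cc(C(F)(F)F)ccc1F` is compound 2 with trifluoromethyl in place of methyl on an aromatic carbon, meta to a large group and para to a fluoro group: trifluoromethyl in place of methyl on an aromatic carbon. Going by the values given here, no measured pair isolates this change. Compound 1 also carries trifluoromethyl and gives 56600 nM, so no shift beyond the scatter is expected in this assay. The expected step is a 1.4-fold lower number from compound 2 to compound 4 (0.14 log units; within the scatter). For compound 4 the estimate is 60000 nM, with an expected range of 25000 nM to 120000 nM.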

Compound 4, half-maximal inhibitory concentration: 10900 nM
Compound 4: the middle estimate sits 5.5-fold (0.74 log units) above what was measured; measured number outside the range, below it.
By their numbers in this assay, from the lowest: compound 4; then compounds 3, 1 and 2 (each within the scatter of the next).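

In this assay, the aromatic carbon meta to a large group and para to a fluoro group is sensitive to its substituent: trifluoromethyl in place of methyl gives a 7.6-fold lower number from compound 2 to compound 4 (0.88 log units; beyond the scatter). Going by these compounds alone, the earlier compounds showed no separation beyond the scatter, so this is the first change with a readable effect. Nothing available explains the step. Going by these compounds, whether an amine, a chloro group or a longer chain such as ethyl on this carbon would give a similar step remains open. Also open, on these data alone, is whether the same change holds with a methoxy group in place of the fluoro group.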